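From benzyl to 4-methylbenzyl: a modest rise expected

The source may report more compounds than this note shows. Statements on the series, on what has been measured and on what is new or still open speak of the compounds shown alone.

In a physicochemical assay for lipophilicity, read by HPLC (a lower number here means a more polar compound, a higher number a more lipophilic compound), compound 2 `Cc1ccsc1C(=CCCN(C)C(CCN)C(=O)NCc1ccccc1)c1sccc1C` gives 5.5 and is the lower of two numbers, while compound 1 `Cc1ccsc1C(=CCCN(C)C(CCN)C(=O)NCc1ccc(Cl)cc1)c1sccc1C` gives 5.85. Compound 3 `Cc1ccc(CNC(=O)C(CCN)N(C)CCC=C(c2sccc2C)c2sccc2C)cc1` carries methyl in place of hydrogen on an aromatic carbon and remains unmeasured. Within the data shown here, no methyl step is available, so the nearest guide is a number 0.35 log units lower from compound 1 to compound 2 (beyond the scatter) where hydrogen replaces chloro, a modest step beyond the scatter. Here hydrogen is the group that leaves, so a rise of similar size in this assay is expected, and the estimated step is a number 0.35 log units higher from compound 2 to compound 3 (beyond the scatter). The estimate for compound 3 is 5.85 with an expected range from 5.6 to 6.1.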

Compound 3, partition coefficient: 6.61
Compound 3: the middle estimate sits 0.76 log units below what was measured; the whole stated range lies below it.
By their numbers in this assay, from the lowest: compound 2; then compound 1; then compound 3.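

In this assay methyl in place of hydrogen at this position gives a number 1.11 log units higher from compound 2 to compound 3 (beyond the scatter) and so one added carbon moves the number much further than the chloro step had shown. Methyl and chloro do not count as equals here, since methyl in place of chloro gives a number 0.76 log units higher from compound 1 to compound 3 (beyond the scatter) and leaves compound 3 with the highest number of the three. Nothing available explains why the methyl step is so large.

As far as these compounds go, whether the number keeps climbing with ethyl or a longer chain at this position remains open. So does the size of the step with an amine or a carboxylic acid there.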